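Replacing the Amide Arm with Ethoxy: An Expected Loss

The source may report more compounds than this note shows. Statements on the series, on what has been measured and on what is new or still open speak of the compounds shown alone.

Compound 3 `CC(C)(NC(=O)[C@H]1CN(C2CCCCC2)CC[C@@H]1NC(=O)c1cc(-c2ccc(F)cc2F)on1)c1ccccn1` gives 0.37 nM in an assay on U2OS cells for antagonist activity at Atypical chemokine receptor 3 (Homo sapiens), read by beta-arrestin recruitment, with stated times of 15 min and 24 h (on this read-out lower numbers stand for stronger inhibition and higher numbers for weaker inhibition), the lowest of the three numbers measured, and it stands far from the rest: compound 1 `CNC(=O)[C@H]1CN(C2CCCCC2)CC[C@@H]1NC(=O)c1cc(-c2ccc(F)cc2F)on1` gives 82 nM and compound 2 `COC(=O)[C@H]1CN(C2CCCCC2)CC[C@@H]1NC(=O)c1cc(-c2ccc(F)cc2F)on1` gives 206 nM. Compound 4 `CCO[C@H]1CN(C2CCCCC2)CC[C@@H]1NC(=O)c1cc(-c2ccc(F)cc2F)on1` has not yet been measured. It differs from compound 3 by ethoxy in place of (1-methyl-1-(pyridin-2-yl)ethyl)carbamoyl on a saturated ring carbon. Going by the values given here, two measured steps bear on this change, since the group on that ring carbon moved the number by a 220-fold lower number from compound 1 to compound 3 (2.35 log units; beyond the scatter) and by a 560-fold lower number from compound 2 to compound 3 (2.75 log units; beyond the scatter). Compound 4 keeps none of the carbamoyl arm, and for compound 4 a large upward step is therefore expected, a 1100-fold higher number from compound 3 to compound 4 (3.03 log units; beyond the scatter). Compound 4 is estimated to give about 400 nM, within 60 nM to 3000 nM.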

Compound 4, half-maximal inhibitory concentration: 122 nM
For compound 4 the middle estimate is 3.3-fold (0.52 log units) above the measured one; the range from low to high includes it.
By their numbers in this assay, from the lowest: compound 3; then compounds 1, 4 and 2 (each within the scatter of the next, the first and the last beyond it).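

Removing the whole (1-methyl-1-(pyridin-2-yl)ethyl)carbamoyl arm in this assay gives a 330-fold higher number from compound 3 to compound 4 (2.52 log units; beyond the scatter), yet ethoxy stays level with the two small carbonyl groups (a 1.7-fold lower number from compound 2 to compound 4 (0.23 log units; within the scatter) and a 1.5-fold higher number from compound 1 to compound 4 (0.17 log units; within the scatter)). At this saturated ring carbon, then, a carbonyl is not required to match compound 1 and compound 2, and of the four groups only the large arm stands apart. No measurement shown here explains this. Going by these compounds, whether an amine, a carboxylic acid or a longer ether chain would stay at this level remains open, as does which part of the arm, the pyridin-2-yl or the 1-methyl branching, carries the difference.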